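Cytotoxicity of dienone analogues: an untested ring-nitrogen substituent

The compounds below may be only part of what the source reports. "The series", "measured", "known", "first", "only" and "open" are said of these compounds alone.

Compounds measured so far:
Compound 1: `CN1C/C(=C\c2ccncc2)C(=O)/C(=C/c2ccccc2F)C1`; 4600 nM
Compound 2: `CN1C/C(=C\c2ccncc2)C(=O)/C(=C/c2ccc(C#N)cc2)C1`; 13900 nM

In a functional assay on HepG2 cells (Homo sapiens) for cytotoxicity, read by MTT assay, with a stated time of 24 h (a lower number here means a stronger inhibitor, a higher number a weaker inhibitor), compound 1 gives 4600 nM, the lowest number among the two compounds measured; its nearest neighbour is compound 2, which in this assay gives 13900 nM. Among the measured compounds shown here, the only step measured so far, a 3.0-fold higher number from compound 1 to compound 2 (0.48 log units; beyond the scatter), arises from 4-cyanophenyl in place of 2-fluorophenyl on a double-bonded chain carbon bound to a double-bonded ring carbon.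

Compound 3, `N#Cc1ccc(S(=O)(=O)N2C/C(=C\c3ccncc3)C(=O)/C(=C/c3ccccc3F)C2)cc1`, has not yet been measured in this assay. It differs from compound 1 at a different place: (4-cyanophenyl)sulfonyl in place of methyl on an amine nitrogen in a ring. For the measured compounds named here, no measured step touches the amine nitrogen in the ring, so the single recorded step offers no direct guide to the effect of this change. The 4-cyanophenyl group that enters here is the same group whose placement on the chain carbon went with the step from compound 1 to compound 2, but that does not transfer to a new position.

Going by the values given here, with no bearing step available, compound 3 is expected to give a number not far from that of compound 1, an estimated step of a 1.2-fold higher number from compound 1 to compound 3 (0.08 log units; within the scatter), with wide uncertainty. Compound 3 is therefore estimated at 5500 nM, within a range of 1500 nM to 20000 nM.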

Compound 3, half-maximal inhibitory concentration: 4500 nM
The estimate for compound 3 lay 1.2-fold (0.09 log units) above the measured number; measured number inside the range.
By their numbers in this assay, from the lowest: compounds 3 and 1 (each within the scatter of the next); then compound 2.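

In this assay, the amine nitrogen in the ring of the six-membered non-aromatic ring now has a reading of its own: replacing methyl, a single carbon, with (4-cyanophenyl)sulfonyl, a group of 11 heavy atoms with one six-membered aromatic ring, gives a 1.0-fold lower number from compound 1 to compound 3 (0.01 log units; within the scatter). Among the steps shown, a large change in the group on this nitrogen therefore leaves the number within the scatter, whereas the smaller exchange on the chain carbon gave a 3.0-fold higher number from compound 1 to compound 2 (0.48 log units; beyond the scatter) and lay beyond it. Nothing available here accounts for the absence of a readable change at the nitrogen.

Going by these compounds, it remains open whether this position would stay as flat with a group of another kind on the nitrogen, such as a benzyl group, an acetyl group or a simple hydrogen, or with a plain phenylsulfonyl group lacking the nitrile. On these data alone, it is also open whether (4-cyanophenyl)sulfonyl on this nitrogen would give a similarly flat step when the chain carbon carries 4-cyanophenyl rather than 2-fluorophenyl.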